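Fluorine on the phenyl ring across two cores

The source may report more compounds than this note shows. Statements on the series, on what has been measured and on what is new or still open speak of the compounds shown alone.

Compound 1 `C(=N/c1ccccc1)\c1cc(-c2ccccc2)no1` and compound 2 `Fc1ccc(-c2cc(/C=N/c3ccccc3)on2)cc1` share one core, and compound 3 `CCc1cc2ccccc2nc1-c1cc(-c2ccccc2)no1` and compound 4 `CCc1cc2ccccc2nc1-c1cc(-c2ccc(F)cc2)no1` share another; the difference between the two cores is not broken down here. In a functional assay on A549 cells (Homo sapiens) for inhibition, read by MTT assay, with a stated time of 24 h (a higher number here means a weaker inhibitor, a lower number a stronger inhibitor), compound 1 gives 48100 nM and compound 2 gives 34500 nM. The change between them, (fluoro in place of hydrogen on an aromatic carbon), made the step of a 1.4-fold lower number from compound 1 to compound 2 (0.14 log units; within the scatter).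

For compound 3 this assay gives only a limit, > 100000 nM. The change from compound 3 to compound 4 is the same, (fluoro in place of hydrogen on an aromatic carbon), and among the compounds shown it occurs twice in all.

Since the measured instance of this change stayed within the scatter, compound 4 is expected to stay close to where compound 3 sits, with an expected step that the limit leaves unreadable from compound 3 to compound 4. That expectation rests on the step of a 1.4-fold lower number from compound 1 to compound 2 (0.14 log units; within the scatter) between the two measured compounds. It also rests on compound 3 sitting at the limit of > 100000 nM in this assay, at which 1 of the 3 values shown sits. In this assay compound 4 is therefore estimated at 120000 nM, with a range from 50000 nM to 300000 nM, and most likely this assay will again report only a limit.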

Compound 4, half-maximal inhibitory concentration: > 100000 nM
Compound 4: no number, only a limit (the forecaster's own chance of this, stated with the estimate: 75%); the middle value lies beyond the limit too.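

Compound 3 and compound 4 both give only a limit in this assay, not a number, so no step between them can be read: the limit of > 100000 nM in this assay, at which 2 of the 4 values shown sit.

The compounds shown leave open whether phenyl to 4-fluorophenyl changes inhibition at all on the core shared by compound 3 and compound 4.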